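Adding a Methyl Group to Compound 2

The source may hold more compounds than are shown below. What is called first, only, known or untested is meant among the compounds shown, and "the series" means these compounds.

Compound 1 `COc1cc(NCc2cccc(O)c2)cc(OC)c1OC` gives 67700 nM in a functional assay on HCT-116 cells (Homo sapiens) for inhibition, read by MTT assay, with a stated time of 48 h; a lower number here means a stronger inhibitor, a higher number a weaker inhibitor.
Compound 2 `COc1cc(NCc2ccccc2)cc(OC)c1OC` gives > 80000 nM in this assay; this is a limit of the assay, not a number.
Compound 3 `C/C=C/C(=O)N(Cc1ccc(OC)c(F)c1)c1cc(OC)c(OC)c(OC)c1` gives 1160 nM in this assay.

Among the measured compounds shown here, compound 2 stands at the limit: the assay reports only that its value lies beyond what can be measured, so no exact number exists for it (the limit of > 80000 nM in this assay, at which 1 of the 3 values shown sits). For the measured compounds named here, compound 1 differs from it only by a hydroxy group on one aromatic carbon, and the step of an at least 1.1-fold higher number from compound 1 to compound 2 (0.07 log units; that floor lies within the scatter) is the one measured change in this set; compound 3 shares the core but differs in several places at once, so its value shows only that a quite different build can reach a far lower number.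

Compound 4 `COc1cc(NCc2ccc(C)cc2)cc(OC)c1OC` is the next compound to be measured in this assay. It differs from compound 2 as follows (methyl in place of hydrogen on an aromatic carbon). Going by the values given here, no measured step involves a methyl group, so the only guide is that removing a hydroxy from compound 1 gave compound 2 a value at the limit, and a methyl adds no donor or acceptor. Compound 4 is therefore expected to sit at or near the same limit, with the step that the limit leaves unreadable from compound 2 to compound 4 estimated as no change beyond the scatter. Compound 4 is estimated at 90000 nM, within 40000 nM to 200000 nM.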

Compound 4, half-maximal inhibitory concentration: > 80000 nM
Compound 4 gave a limit, no number (the forecaster's own chance of this, stated with the estimate: 70%); the middle value lies beyond the limit too.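

In this assay compound 4 gives > 80000 nM, which is a limit of the assay and not a number, so a methyl group on the aromatic ring, para to a large group, does not yield a measurable value here. The step between compound 2 and compound 4 cannot be read, since both sit at the limit: the methyl group may have changed nothing, or it may have changed the true value somewhere out of the assay's reach. The one readable comparison is an at least 1.1-fold higher number from compound 1 to compound 4 (0.07 log units; that floor lies within the scatter), so it does not separate these compounds by more than ordinary repeat variation, and the limit now holds a larger share of the set: the limit of > 80000 nM in this assay, at which 2 of the 4 values shown sit.

On these data alone, how far beyond the limit compound 2 and compound 4 truly lie, and whether they differ from each other at all, stays open. Also open, as far as these compounds go, is whether an amine, a carboxylic acid or a longer chain in place of the methyl group, at this same place on the ring, would bring the value down to a number that can be measured.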